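From a Fluorinated Aryl to a Nitrile-Bearing Aryl

The source may hold more compounds than are shown below. What is called first, only, known or untested is meant among the compounds shown, and "the series" means these compounds.

Compound 1 `FC(F)(F)c1ccccc1NC(=S)N/N=C/c1ccc2ccccc2n1` bears a trifluoromethyl group, and in a functional assay on HL-60 cells (Homo sapiens) for antiproliferative activity, read by sulforhodamine B assay, with a stated time of 72 h (a lower number here means a stronger inhibitor, a higher number a weaker inhibitor), compound 1 gives 13200 nM. Compound 2 `Fc1ccccc1NC(=S)N/N=C/c1ccc2ccccc2n1` keeps the shared core but has fluoro in place of trifluoromethyl on an aromatic carbon. In this assay compound 2 gives > 100000 nM, which is a limit of the assay and not a number (the limit of > 100000 nM in this assay, at which 1 of the 2 values shown sits). Going by the values given here, the single measured step, an at least 7.5-fold higher number from compound 1 to compound 2 (0.87 log units; beyond the scatter), therefore shows only that this small change on the aryl group weakened inhibition by an at least modest amount, leaving compound 2 at the top edge of what the assay reports.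

Compound 3 `N#Cc1ccc(NC(=S)N/N=C/c2ccc3ccccc3n2)cc1` differs from compound 2 by 4-cyanophenyl in place of 2-fluorophenyl on an amide-type nitrogen. Among the compounds with values here, no measured step covers this exchange. Within the data shown here, the only step at hand, an at least 7.5-fold higher number from compound 1 to compound 2 (0.87 log units; beyond the scatter), shows that altering the substituent on this aryl group can move the number by an at least modest amount, so a change beyond the scatter is plausible in either direction. The expected step is an at least 2.0-fold lower number from compound 2 to compound 3 (0.30 log units; that floor lies within the scatter), read with caution since compound 2 is known only as a limit. Compound 3 is estimated at 50000 nM, within a range from 10000 nM to 150000 nM.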

Compound 3, half-maximal inhibitory concentration: 4660 nM
Compound 3: the middle estimate sits 11-fold (1.03 log units) above what was measured; measured number outside the range, below it.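

Going by these compounds alone, until now the only step on this aryl group had raised the number, whereas in this assay the exchange of 2-fluorophenyl for 4-cyanophenyl on the amide-type nitrogen gives an at least 21-fold lower number from compound 2 to compound 3 (1.33 log units; beyond the scatter). This position can therefore move the number in both directions, and compound 3 shows that a nitrile-bearing aryl group can recover inhibition from a compound at the top edge of the readout. The true size of this step remains unknown, and the printed size is only a floor, since compound 2 is known only as a limit: the limit of > 100000 nM in this assay, at which 1 of the 3 values shown sits.

The step replaces 2-fluorophenyl with 4-cyanophenyl as a whole, so the compounds shown cannot separate the contribution of the nitrile from that of the other differences between the two aryl groups. As far as these compounds go, it also remains open how an unsubstituted phenyl, or a phenyl carrying an amine or a carboxylic acid, would behave on the same nitrogen, and therefore whether the lower number of compound 3 is particular to the nitrile.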